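Benzyl gives way to allyl

The source may hold more compounds than are shown below. What is called first, only, known or untested is meant among the compounds shown, and "the series" means these compounds.

In a physicochemical assay for lipophilicity, read by HPLC, using the shake flask method (on this read-out lower numbers stand for lower lipophilicity and higher numbers for higher lipophilicity), compound 1 `C/C(=N\C#N)N(Cc1ccccc1)Cc1ccc(Cl)nc1` gives 2.11, the higher of the two numbers in hand. Compound 2 `CCC/C(=N\C#N)N(C)Cc1ccc(Cl)nc1` gives 1.55, and the gap between the two lies beyond the scatter. Compound 3 `C=CCN(Cc1ccc(Cl)nc1)/C(C)=N/C#N` has not yet been measured. It keeps the core of compound 1 and differs from it in one place: vinyl in place of phenyl on a saturated chain carbon bound to an amine nitrogen. Cut one bond further out, the same difference reads benzyl to allyl. Within the data shown here, no step between measured compounds shows what such a change does in this assay. The expectation therefore rests on the structural change alone. A fall beyond the scatter is expected, with a number 0.81 log units lower from compound 1 to compound 3 (beyond the scatter) as the estimated step. For compound 3 the estimated value is 1.3, with an expected range from 1 to 1.6.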

Compound 3, partition coefficient: 1.56
Compound 3: the middle estimate sits 0.26 log units below what was measured; the range from low to high includes it.
By their numbers in this assay, from the lowest: compounds 2 and 3 (each within the scatter of the next); then compound 1.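

In this assay the change of vinyl in place of phenyl on a saturated chain carbon bound to an amine nitrogen gives the first step read at this position, a number 0.55 log units lower from compound 1 to compound 3 (beyond the scatter), so this place on the core of compound 1 does register a change of group. The phenyl that leaves brings one six-membered aromatic ring of carbon only, the vinyl that enters brings no ring, and both count no hydrogen-bond donors or acceptors, so the step goes with a loss of ring and of heavy atoms and not with a change in those counts. Nothing measured on these compounds accounts for the size of the step.

One step cannot tell the loss of the ring apart from the loss of size. Going by these compounds, how a cyclohexyl group or a longer chain would read at this place remains open.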